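A thiazolyl amine in place of a chlorophenyl

The source may hold more compounds than are shown below. What is called first, only, known or untested is meant among the compounds shown, and "the series" means these compounds.

compound 1 `Cc1cc(=O)oc2cc(OC(=O)CNc3ccccc3Cl)ccc12` 21.4%
compound 2 `Cc1cc(=O)oc2cc(OC(=O)CNc3ccc(Cl)cc3)ccc12` 10.7%

In a functional assay on the whole organism (strain Wistar albino) for inhibition, with Rattus norvegicus as the target, read by paw edema, with stated times of 30 min and 1 h, at a dose of 20 mg/kg by the oral route (a lower number here means less inhibition, a higher number more inhibition at the dose given (going by the name of the read-out)), compound 1 gives 21.4%, while compound 2 gives 10.7%. For the measured compounds named here, compound 2 stands lowest of the two numbers; the only measured step is a number 10.7 percentage points lower from compound 1 to compound 2 (beyond the scatter). Compound 3 `Cc1cc(=O)oc2cc(OC(=O)CNc3nccs3)ccc12` differs from compound 2 by 1,3-thiazol-2-yl in place of 4-chlorophenyl on an amine nitrogen. Going by the values given here, no measured step bears on this change, since the step from compound 1 to compound 2 exchanges only one chlorophenyl for another. For compound 3 the step of a number 4.3 percentage points higher from compound 2 to compound 3 (within the scatter) is therefore expected to stay within the scatter, with no clear direction. Compound 3 is estimated at 15%, between 3% and 32%.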

Compound 3, a percentage reported as inhibition, in the whole organism at one dose (the size of the read-out at that dose, not a potency): 39.2%
For compound 3 the middle estimate is 24.2 percentage points below the measured one, outside the stated range (above it).
By their numbers in this assay, from the lowest: compound 2; then compound 1; then compound 3.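

On the amine nitrogen, the group need not be a chlorophenyl: in this assay, 1,3-thiazol-2-yl in place of 4-chlorophenyl gives a number 28.5 percentage points higher from compound 2 to compound 3 (beyond the scatter), and in place of 2-chlorophenyl it gives a number 17.8 percentage points higher from compound 1 to compound 3 (beyond the scatter). This puts compound 3 highest of the three, and the change of ring moves the number further than the earlier shift of chlorine did. No supporting evidence accounts for this gain. As far as these compounds go, it remains open whether a pyridin-2-yl or a cyclohexyl group on the same nitrogen would keep the number, and whether any ring is needed there at all.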